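Swapping the benzamide aryl group of a P2X7 antagonist

This account rests on a few compounds, and the source may have more. Where it says the series, first, only, none or still open, it means among the compounds named here.

Three compounds share a core in which an aromatic ring bears an oxygen-linked substituent. Compound 1 `CS(=O)(=O)Oc1ccc(-c2cncn2C2CCN(C(=O)c3ccc(Cl)c(C(F)(F)F)c3)CC2)cc1` carries a methylsulfonyl group there and gives 1570 nM in an assay on HEK293 cells for antagonist activity at P2X purinoceptor 7 (Homo sapiens), read by fluorescence, with a stated time of 2 h; on this read-out higher numbers stand for weaker inhibition and lower numbers for stronger inhibition. Compound 2 `O=C(Oc1ccc(-c2cncn2C2CCN(C(=O)c3ccc(Cl)c(C(F)(F)F)c3)CC2)cc1)c1ccccc1` carries a benzoyl group instead, and in this assay compound 2 reaches only the limit > 10000 nM (the limit of > 10000 nM in this assay, at which 1 of the 3 values shown sits). Compound 3 `N#Cc1cccc(S(=O)(=O)Oc2ccc(-c3cncn3C3CCN(C(=O)c4ccc(Cl)c(C(F)(F)F)c4)CC3)cc2)c1` carries a (3-cyanophenyl)sulfonyl group and gives 73 nM, the lowest number of the set: the step of a 22-fold lower number from compound 1 to compound 3 (1.33 log units; beyond the scatter) and the step of an at least 130-fold lower number from compound 2 to compound 3 (2.13 log units; beyond the scatter) both run in its favour.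

Compound 4 `CS(=O)(=O)c1ccc(C(=O)N2CCC(n3cncc3-c3ccc(OS(=O)(=O)c4cccc(C#N)c4)cc3)CC2)cc1` differs from compound 3 at another place: 4-(methylsulfonyl)phenyl in place of 4-chloro-3-(trifluoromethyl)phenyl on a carbonyl carbon. Going by the values given here, every measured step concerns the oxygen-linked substituent, so none of them bears on a change at the carbonyl carbon, and no measured step informs the size or direction of the expected change. Compound 4 is therefore expected, with wide uncertainty, to give 500 nM, between 80 nM and 3000 nM. This estimate corresponds to an expected step of a 6.8-fold higher number from compound 3 to compound 4 (0.84 log units; beyond the scatter).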

Compound 4, half-maximal inhibitory concentration: 143 nM
Compound 4: middle estimate off by 3.5-fold (0.54 log units), on the high side; low and high end bracket the measured number.
By their numbers in this assay, from the lowest: compounds 3 and 4 (each within the scatter of the next); then compound 1. At a limit, above all of these: compound 2.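

Going by these compounds alone, with the (3-cyanophenyl)sulfonyl group held on the oxygen, the first change at the carbonyl carbon, in this assay, gives a 2.0-fold higher number from compound 3 to compound 4 (0.29 log units; within the scatter) as its step. All earlier steps concerned the oxygen-linked substituent and lay beyond the scatter, whereas this pair shows that, here, 4-(methylsulfonyl)phenyl can stand in place of 4-chloro-3-(trifluoromethyl)phenyl with no difference beyond the scatter, even though the chlorine and the trifluoromethyl group both leave. Nothing available accounts for this outcome.

On these data alone, whether the same swap behaves alike when the oxygen carries the methylsulfonyl group of compound 1 remains open. Also open, as far as these compounds go, is what the aryl ring on the carbonyl carbon would give with a carboxylic acid or an amine in place of the methylsulfonyl group.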